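Chloro to methyl on the coumarin-side fragment: series notes

The source may report more compounds than this note shows. Statements on the series, on what has been measured and on what is new or still open speak of the compounds shown alone.

Measured so far in an assay on isolated protein for inhibition of Amine oxidase [flavin-containing] B (Homo sapiens), read by fluorescence, with a stated time of 15 min; on this read-out lower numbers stand for stronger inhibition and higher numbers for weaker inhibition:
compound 1 `COc1ccc(/C=C/c2cc(OC)cc(OC)c2/C=C/C(=O)c2cc3ccccc3oc2=O)cc1` gives 9170 nM
compound 2 `COc1ccc(/C=C/c2cc(OC)cc(OC)c2/C=C/C(=O)c2cc3ccc(Br)cc3oc2=O)cc1` gives 55300 nM
compound 3 `COc1ccc(/C=C/c2cc(OC)cc(OC)c2/C=C/C(=O)c2cc3ccc(Cl)cc3oc2=O)cc1` gives 7360 nM

Compound 3 shows the lowest number of the three, but its gap to compound 1 is within the scatter, so the two are not separable on this read-out. The clear step is a 7.5-fold lower number from compound 2 to compound 3 (0.88 log units; beyond the scatter), matched by a 6.0-fold higher number from compound 1 to compound 2 (0.78 log units; beyond the scatter) in the other direction, whereas a 1.2-fold lower number from compound 1 to compound 3 (0.10 log units; within the scatter) stays within the scatter.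

Compound 4 `COc1ccc(/C=C/c2cc(OC)cc(OC)c2/C=C/C(=O)c2cc3cccc(C)c3oc2=O)cc1` differs from compound 3 by a group of 12 heavy atoms (10 carbon, 2 oxygen; one six-membered aromatic ring of carbon only, one six-membered aromatic ring with 1 hetero atom) in place of a group of 12 heavy atoms (9 carbon, 2 oxygen, 1 chlorine; one six-membered aromatic ring of carbon only, one six-membered aromatic ring with 1 hetero atom), on a carbonyl carbon: the incoming fragment carries a methyl where the outgoing one carried a chlorine. Among the measured compounds shown here, no measured step covers a methyl in this part of the molecule. What bears on the change is that removing chloro from compound 3 to give compound 1 costs nothing beyond the scatter, while bromo in compound 2 gives a modestly higher number. A methyl-bearing fragment is therefore expected to land near compound 1 and compound 3, with the possibility of a modest rise as seen for compound 2. For compound 4 the estimate is 10000 nM in this assay, with a range from 3500 nM to 30000 nM, which is expected to correspond to a step of a 1.4-fold higher number from compound 3 to compound 4 (0.13 log units; within the scatter).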

Compound 4, half-maximal inhibitory concentration: 20000 nM
Compound 4: middle estimate off by 2.0-fold (0.30 log units), on the low side; low and high end bracket the measured number.
By their numbers in this assay, from the lowest: compounds 3 and 1 (each within the scatter of the next); then compound 4; then compound 2.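

In this assay, among the compounds shown here, adding a methyl to this fragment gives a 2.2-fold higher number from compound 1 to compound 4 (0.34 log units; beyond the scatter), so this fragment does not accept every small addition as neutrally as the chloro step suggested; bromo is no longer the only substituent with a step beyond the scatter from compound 1. Replacing the chlorine-bearing fragment on the carbonyl carbon with the methyl-bearing one gives a 2.7-fold higher number from compound 3 to compound 4 (0.43 log units; beyond the scatter), while replacing the bromine-bearing fragment with it gives a 2.8-fold lower number from compound 2 to compound 4 (0.44 log units; beyond the scatter), which places compound 4 clearly apart from both halogen compounds, with compound 2 still the highest number of the set. No supporting measurement bears on why these substituents differ.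

Still open, from the compounds shown here alone, is how a fluoro, an amine or a carboxylic acid on this fragment would read in this assay, and so whether chloro or the unsubstituted fragment marks the lower end of the range. Also open, going by these compounds, is whether the same ranking of hydrogen, chloro, methyl and bromo would hold if the methoxy groups on the shared core were replaced by a hydroxyl.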